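Two weak inhibitors and a smaller aryl group

The compounds below may be only part of what the source reports. "The series", "measured", "known", "first", "only" and "open" are said of these compounds alone.

Measured compounds:
compound 1, `NS(=O)(=O)Nc1ccc(-c2cn(Cc3cc(C(=O)O)cc(-c4ccccc4C(=O)O)c3)nn2)cc1`, 84500 nM
compound 2, `CC(=O)Nc1ccc(-c2cn(Cc3cc(C(=O)O)cc(-c4ccccc4C(=O)O)c3)nn2)cc1`, 80900 nM

In an assay on cells for inhibition of ubiquitin carboxyl-terminal hydrolase isozyme L5 (Homo sapiens), read by fluorescence, with a stated time of 30 min (a lower number here means a stronger inhibitor, a higher number a weaker inhibitor), compound 2 gives 80900 nM, the lowest of the two numbers, while compound 1 gives 84500 nM, so the two stand within the scatter of each other. Within the data shown here, the one measured step, a 1.0-fold lower number from compound 1 to compound 2 (0.02 log units; within the scatter), shows that exchanging the group on the ring nitrogen leaves the number where it was.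

Compound 3, `Nc1cccc(-c2cn(Cc3cc(C(=O)O)cc(-c4ccccc4C(=O)O)c3)nn2)c1`, is the next compound. It differs from compound 2 in that (3-aminophenyl in place of 4-acetamidophenyl on an aromatic carbon), a change on an aromatic carbon of the five-membered aromatic ring with 3 nitrogen. Among the measured compounds shown here, no measured step touches this change directly; the only step at hand, on the same phenyl ring, was within the scatter. On that basis compound 3 is expected to stay close to compound 2, with an estimated step of a 1.0-fold lower number from compound 2 to compound 3 (0.00 log units; within the scatter) and an estimated value of 80000 nM, between 30000 nM and 200000 nM.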

Compound 3, half-maximal inhibitory concentration: 72600 nM
Beside the measured number, compound 3's estimate is 1.1-fold (0.04 log units) above it; the range from low to high includes it.
By their numbers in this assay, from the lowest: compounds 3, 2 and 1 (each within the scatter of the next).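

In this assay, replacing 4-acetamidophenyl with 3-aminophenyl gives a 1.1-fold lower number from compound 2 to compound 3 (0.05 log units; within the scatter) and so leaves the number where it was. Against the 4-(sulfamoylamino)phenyl group the result is the same, with a 1.2-fold lower number from compound 1 to compound 3 (0.07 log units; within the scatter) as the step, so the aromatic carbon of the five-membered aromatic ring tolerates both a shorter group and a different point of attachment on the phenyl ring, at least among these weak inhibitors. No evidence is available to explain this flat result.

From the compounds shown here alone, the amino group's ring position and the group's size changed together here, so their separate contributions remain unknown. Also open, going by these compounds, is whether a 4-aminophenyl group, or a phenyl ring bearing a carboxylic acid, would move the number beyond the scatter.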